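Chloro to trifluoromethyl on the benzyl ring: a second look

The source may report more compounds than this note shows. Statements on the series, on what has been measured and on what is new or still open speak of the compounds shown alone.

Compound 1, `CCN(Cc1cccc(Cl)c1)C(=O)C1CCN(S(=O)(=O)c2ccc3cn[nH]c3c2)CC1`, gives 77% in a functional assay on CHO cells for positive allosteric modulation of muscarinic acetylcholine receptor M5 (Homo sapiens), read by calcium flux; a higher number here means a larger maximal response, a lower number a smaller maximal response.
Compound 2, `CCN(Cc1cccc(C(F)(F)F)c1)C(=O)C1CCN(S(=O)(=O)c2ccc3cn[nH]c3c2)CC1`, gives 59% in this assay.
Compound 3, `CCN(Cc1ccccc1Cl)C(=O)C1CCN(S(=O)(=O)c2ccc3[nH]ncc3c2)CC1`, gives 78% in this assay.

Compound 1 and compound 2 differ by trifluoromethyl in place of chloro on an aromatic carbon, and in this assay this gave a number 18 percentage points lower from compound 1 to compound 2 (beyond the scatter). Compound 3 carries the same atoms as compound 1 joined differently; the difference between the two cores is not broken down here, and their two values lie within the scatter of each other.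

Compound 4, `CCN(Cc1ccccc1C(F)(F)F)C(=O)C1CCN(S(=O)(=O)c2ccc3[nH]ncc3c2)CC1`, is not yet measured. It differs from compound 3 by trifluoromethyl in place of chloro on an aromatic carbon. The group enters ortho to a large group here, whereas from compound 1 to compound 2 it entered meta to a large group, so this is the same kind of change, not the same change. Because a number 18 percentage points lower from compound 1 to compound 2 (beyond the scatter), a step of about a number 18 percentage points lower from compound 3 to compound 4 (beyond the scatter) is expected for compound 4 in this assay. Compound 4 is thus estimated at 60%, within 45% to 76%.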

Compound 4, largest response reached (reported as percent of maximum), in percent of the reference or control that the assay uses: 96%
For compound 4 the middle estimate is 36 percentage points below the measured one; the measured number lies above the stated range.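

In this assay, trifluoromethyl in place of chloro gave a number 18 percentage points higher from compound 3 to compound 4 (beyond the scatter). The change therefore does not carry over from one core to another in this series with a fixed direction, and a step read on one pair is a poor guide to the other: the same change on two cores in this assay, a number 18 percentage points lower (beyond the scatter) from compound 1 to compound 2 and a number 18 percentage points higher (beyond the scatter) from compound 3 to compound 4, 36 percentage points apart, beyond the scatter of two such steps
The two pairs differ both in the core and in where the group sits on the benzyl ring, and these two compound pairs cannot separate those differences or show which one accounts for the gap.

Open, from the compounds shown here alone, is whether the 2-(trifluoromethyl)benzyl group gives the same result on the core of compound 1. Also open, going by these compounds, is how a methoxy or a nitrile in place of trifluoromethyl would read in this assay.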